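The source may report more compounds than this note shows. Statements on the series, on what has been measured and on what is new or still open speak of the compounds shown alone.

Compound 1, `CCCS(=O)(=O)Nc1ccc(F)c(C(=O)c2n[nH]c3ncc(-c4cccc(C)c4)cc23)c1F`: 15%
Compound 2, `CCCS(=O)(=O)Nc1ccc(F)c(C(=O)c2n[nH]c3ncc(-c4ccccc4N)cc23)c1F`: 23%

Of the compounds shown here, two have been measured in an assay for binding affinity to dual specificity mitogen-activated protein kinase kinase 4 (Homo sapiens), read by KINOMEscan, tested at 100 nM; on this read-out higher numbers stand for a weaker effect at the one concentration tested and lower numbers for a stronger effect. In this assay compound 1 gives 15%, and compound 2 gives 23%. The two share the same core and differ only in the aromatic group attached to one carbon of that core. Going by the values given here, the single measured step, a number 8 percentage points higher from compound 1 to compound 2 (within the scatter), falls within the scatter, so the two readings cannot be told apart, and compound 2 stands simply alongside compound 1 with no ranking between them.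

Compound 3, `CCCS(=O)(=O)Nc1ccc(F)c(C(=O)c2n[nH]c3ncc(-c4cc(Cl)cc(Cl)c4)cc23)c1F`, has not yet been measured. Compared with compound 2 the change is 3,5-dichlorophenyl in place of 2-aminophenyl on an aromatic carbon. Among the compounds with values here, this is the same position that was varied in the one measured step, and there the exchange of groups, a number 8 percentage points higher from compound 1 to compound 2 (within the scatter), produced nothing beyond the scatter. Within the data shown here, no compound carrying a 3,5-dichlorophenyl group has been tested, so there is no direct evidence for it; the only guide is that swapping groups at this carbon has so far left the reading unchanged within scatter.

The step from compound 2 to compound 3 is therefore expected to be a number 3 percentage points lower from compound 2 to compound 3 (within the scatter), with no direction beyond the scatter. Compound 3 is estimated at 20% in this assay, within a range of 5% to 45%.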

Compound 3, a percentage reported as activity, at one concentration (the size of the read-out at that concentration, not a potency): 73%
Estimate against measurement, compound 3: 53 percentage points below; the measured number lies above the stated range.
By their numbers in this assay, from the lowest: compounds 1 and 2 (each within the scatter of the next); then compound 3.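

At this carbon of the shared core, the aromatic group can matter a great deal in this assay: 3,5-dichlorophenyl gives a number 50 percentage points higher from compound 2 to compound 3 (beyond the scatter) and a number 58 percentage points higher from compound 1 to compound 3 (beyond the scatter) on a read-out where a higher number means a weaker effect. The earlier exchange between 3-methylphenyl and 2-aminophenyl stayed within the scatter, so that pair gave a misleading impression of a position open to any aryl group, and among the three compounds only 3,5-dichlorophenyl stands apart. Nothing available explains why this group behaves so differently from the other two.

The compounds shown leave open whether the weaker effect goes with the chlorine atoms themselves or with their pattern of substitution on the ring, since compound 3 is the only compound here that carries either feature. A plain phenyl group or a methoxyphenyl group at the same carbon would help show how far the reading depends on what the ring carries, and how much of the effect at this single concentration can be recovered.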